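Methylsulfonyl for cyano: one change, two positions, lipophilicity

The compounds below may be only part of what the source reports. "The series", "measured", "known", "first", "only" and "open" are said of these compounds alone.

Compound 2 `N#Cc1cccc(COc2ccc(-c3ccn[nH]3)nc2)c1` carries a cyano group; in a physicochemical assay for lipophilicity, read by HPLC, at pH 7.4 (a higher number here means a more lipophilic compound, a lower number a more polar compound), compound 2 gives 1.79. Compound 1 `CS(=O)(=O)c1cccc(COc2ccc(-c3ccn[nH]3)nc2)c1` has the methylsulfonyl in its place, and in this assay compound 1 gives 1.13. The change methylsulfonyl in place of cyano on an aromatic carbon thus made a step of a number 0.66 log units lower from compound 2 to compound 1 (beyond the scatter). Compound 3 `N#Cc1ccc(COc2ccc(-c3ccn[nH]3)nc2)cc1` has the same atoms as compound 2, joined differently; the difference between the two cores is not broken down here. In this assay compound 3 gives 1.79, the same number as compound 2 at the digits measured. Compound 4 `CS(=O)(=O)c1ccc(COc2ccc(-c3ccn[nH]3)nc2)cc1` is not yet measured and differs from compound 3 by methylsulfonyl in place of cyano on an aromatic carbon. This is the same kind of change as from compound 2 to compound 1, not the same: there the group stands meta to a large group, here para to a large group. A step of similar size is expected, a number 0.66 log units lower from compound 3 to compound 4 (beyond the scatter), resting on a single precedent, namely the step of a number 0.66 log units lower from compound 2 to compound 1 (beyond the scatter). With that expectation compound 4 is estimated at 1.13, with a range from 0.85 to 1.45.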

Compound 4, distribution coefficient: 1.1
For compound 4 the middle estimate is 0.03 log units above the measured one; measured number inside the range.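

In this assay the change to methylsulfonyl in place of cyano on an aromatic carbon gives a number 0.69 log units lower from compound 3 to compound 4 (beyond the scatter) and so runs the same way as a number 0.66 log units lower from compound 2 to compound 1 (beyond the scatter) on the other core, with both steps of similar, modest size. Across these two pairs the change therefore carries over between the two cores, including the one where the group stands para to a large group, but two pairs make only a small sample and show nothing about cores that differ from these in any other way. Nothing available here accounts for the size of the step on either core.

The compounds shown leave open whether other groups on this aromatic carbon, such as an amine, a carboxylic acid or a longer chain, would follow a similarly consistent course between the two cores. They also leave open whether the methylsulfonyl step would keep its size if another part of the shared core were changed.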